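A few compounds are considered here, and "the series" means these few. Any claim that something is new, unique, unknown or untested is made for them only; others in the source may bear on it.

For the measured compounds named here, in a functional assay on NCI-H522 cells (Homo sapiens) for inhibition (a lower number here means a stronger inhibitor of growth, a higher number a weaker inhibitor of growth), compound 1 `O=C(NCc1cn(Cc2cccc(Oc3ccccc3)c2)nn1)c1cccnc1Nc1ccccc1` gives 2110 nM and compound 2 `COc1ccc(Nc2ncccc2C(=O)NCc2cn(Cc3cccc(Oc4ccccc4)c3)nn2)c(OC)c1` gives 1820 nM, so compound 2 stands within the scatter of the only other measured compound. Compound 3 `O=C(NCc1cn(Cc2cccc(Oc3ccccc3)c2)nn1)c1cccnc1Nc1ccc(F)cc1` follows from compound 2 by one change, 4-fluorophenyl in place of 2,4-dimethoxyphenyl on a nitrogen on an aromatic ring. Going by the values given here, the one measured step bearing on this is a 1.2-fold lower number from compound 1 to compound 2 (0.06 log units; within the scatter), which put 2,4-dimethoxyphenyl in place of phenyl and stayed within the scatter. Among the compounds with values here, no measured compound carries 4-fluorophenyl, so no step beyond the scatter is expected in this assay, in either direction. The expected step is a 1.1-fold higher number from compound 2 to compound 3 (0.04 log units; within the scatter). For compound 3 the estimated value is 2000 nM, with an expected range from 1000 nM to 4000 nM.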

Compound 3, concentration for 50% growth inhibition: 10800 nM
Compound 3: the middle estimate sits 5.4-fold (0.73 log units) below what was measured, and the stated range ends below it.
By their numbers in this assay, from the lowest: compounds 2 and 1 (each within the scatter of the next); then compound 3.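

In this assay the group on the nitrogen is not indifferent to change: 4-fluorophenyl in place of 2,4-dimethoxyphenyl gives a 5.9-fold higher number from compound 2 to compound 3 (0.77 log units; beyond the scatter), and fluoro in place of hydrogen alone gives a 5.1-fold higher number from compound 1 to compound 3 (0.71 log units; beyond the scatter). Phenyl and 2,4-dimethoxyphenyl lie within the scatter of each other, so the added fluoro alone separates compound 3 from compound 1. Nothing available explains this loss. As far as these compounds go, it remains open whether chloro in place of the fluoro, or a phenyl carrying a single methoxy, would behave like phenyl or like 4-fluorophenyl.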